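Swapping Fluoro for Chloro in a Small Anilide Series

A few compounds are considered here, and "the series" means these few. Any claim that something is new, unique, unknown or untested is made for them only; others in the source may bear on it.

Of the compounds shown here, three sharing one core have been tested in a functional assay on NCI-H1975 cells (Homo sapiens) for inhibition, read by MTT assay, with a stated time of 72 h; on this read-out higher numbers stand for weaker inhibition and lower numbers for stronger inhibition. Compound 1 `C=CC(=O)Nc1cccc(NC(=O)CSc2nc(Nc3ccccc3F)c3ccccc3n2)c1` gives 6580 nM, compound 2 `C=CC(=O)Nc1cccc(NC(=O)CSc2nc(Nc3ccccc3Cl)c3ccccc3n2)c1` gives 10000 nM, and compound 3 `C=CC(=O)Nc1cccc(NC(=O)CSc2nc(Nc3cccc(F)c3)c3ccccc3n2)c1` gives 2030 nM. Compound 3 differs from compound 1 by 3-fluorophenyl in place of 2-fluorophenyl on a nitrogen on an aromatic ring, a rearrangement that produced a 3.2-fold lower number from compound 1 to compound 3 (0.51 log units; beyond the scatter). Compound 2 differs from compound 1 by chloro in place of fluoro on an aromatic carbon, which produced a 1.5-fold higher number from compound 1 to compound 2 (0.18 log units; within the scatter). Compound 4 `C=CC(=O)Nc1cccc(NC(=O)CSc2nc(Nc3cccc(Cl)c3)c3ccccc3n2)c1` has not been measured; it differs from compound 3 by chloro in place of fluoro on an aromatic carbon. This is the same kind of change as before, but here the exchanged atom sits meta to a large group rather than ortho to a large group. Compound 4 is therefore expected to give 2700 nM, with a likely range from 1200 nM to 6500 nM. The expected step is a 1.3-fold higher number from compound 3 to compound 4 (0.12 log units; within the scatter), resting on the earlier result a 1.5-fold higher number from compound 1 to compound 2 (0.18 log units; within the scatter), which stayed within the scatter.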

Compound 4, half-maximal inhibitory concentration: 9460 nM
Compound 4: middle estimate off by 3.5-fold (0.54 log units), on the low side, outside the stated range (above it).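

In this assay, chloro in place of fluoro does not carry over as a step of one fixed size: the same change on two cores in this assay, a 1.5-fold higher number (0.18 log units; within the scatter) from compound 1 to compound 2 and a 4.7-fold higher number (0.67 log units; beyond the scatter) from compound 3 to compound 4, 3.1-fold (0.49 log units) apart, beyond the scatter of two such steps. The new result is a 4.7-fold higher number from compound 3 to compound 4 (0.67 log units; beyond the scatter), while the other two comparisons stay level, with a 1.1-fold lower number from compound 2 to compound 4 (0.02 log units; within the scatter) and a 1.4-fold higher number from compound 1 to compound 4 (0.16 log units; within the scatter), so only compound 3 stands apart from the rest. Two pairs show that the same swap can give different steps in this series, but they do not show why, or what the swap would do on a further core.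

On these data alone, whether a 3-methylphenyl or 3-methoxyphenyl group would match compound 3 or compound 4 remains open. So does whether a 3-bromophenyl group would follow the chloro result.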